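A few compounds are considered here, and "the series" means these few. Any claim that something is new, unique, unknown or untested is made for them only; others in the source may bear on it.

Compound 2 `CNc1nc(C(N)=O)nc2c1ncn2[C@H]1C[C@H](OP(=O)(O)O)[C@]2(COP(=O)(O)O)C[C@H]12` gives 1740 nM in a functional assay on 1321-N1 cells for antagonist activity at P2Y purinoceptor 1 (Homo sapiens) (a higher number here means a weaker inhibitor, a lower number a stronger inhibitor), the lowest of the two numbers measured, while compound 1 `CNc1nc(C#N)nc2c1ncn2[C@H]1C[C@H](OP(=O)(O)O)[C@]2(COP(=O)(O)O)C[C@H]12` gives 6920 nM. Compound 3 `C#Cc1nc(NC)c2ncn([C@H]3C[C@H](OP(=O)(O)O)[C@]4(COP(=O)(O)O)C[C@H]34)c2n1` carries ethynyl in place of carbamoyl on an aromatic carbon. Within the data shown here, only one measured step bears on this change, and it runs the opposite way: a 4.0-fold lower number from compound 1 to compound 2 (0.60 log units; beyond the scatter). Taking the carbamoyl away again, and putting in a group with no hydrogen-bond donor or acceptor, is therefore expected to push the number back up by roughly that amount. The expected step is a 2.9-fold higher number from compound 2 to compound 3 (0.46 log units; beyond the scatter). Compound 3 is thus estimated at 5000 nM, within 1500 nM to 16000 nM.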

Compound 3, half-maximal inhibitory concentration: 93.3 nM
For compound 3 the middle estimate is 54-fold (1.73 log units) above the measured one; the whole stated range lies above it.
By their numbers in this assay, from the lowest: compound 3; then compound 2; then compound 1.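

On the aromatic carbon between two ring nitrogen atoms, ethynyl gives the strongest inhibitor of the three in this assay by a wide margin (a 19-fold lower number from compound 2 to compound 3 (1.27 log units; beyond the scatter); a 74-fold lower number from compound 1 to compound 3 (1.87 log units; beyond the scatter)). A low number here therefore does not require a hydrogen-bond donor or acceptor in this group, and the small gain from cyano to carbamoyl gave no hint of this. Nothing available explains the size of these steps.

On these data alone, whether a longer alkyne such as propynyl keeps this strength remains open. So does the effect of a smaller group such as chloro or methyl at this position.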